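The source may report more compounds than this note shows. Statements on the series, on what has been measured and on what is new or still open speak of the compounds shown alone.

Measured in a functional assay on MC-38 cells (Mus musculus) for antiproliferative activity, read by CCK-8 assay, with a stated time of 48 h; a lower number here means a stronger inhibitor, a higher number a weaker inhibitor:
- compound 1 `COc1ccc(/C=C\c2cc(OC)c(OC)c(OC)c2)cc1OCc1ccc(CN2CCCC[C@@H]2C(=O)O)cc1`: > 10000 nM (a limit)
- compound 2 `COc1ccc(/C=C\c2cc(OC)c(OC)c(OC)c2)cc1OCc1ccc(CN[C@H](C(=O)O)[C@H](C)O)cc1`: > 10000 nM (a limit)
- compound 3 `COc1ccc(/C=C\c2cc(OC)c(OC)c(OC)c2)cc1OCc1ccc(CN2CCCCC2C(=O)NCCNC(=O)OC(C)(C)C)cc1`: 1900 nM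

Compound 2 stands only as a limit, so there is no number to step from. Next is compound 4 `COc1ccc(/C=C\c2cc(OC)c(OC)c(OC)c2)cc1OCc1ccc(CN2CC[C@H](O)C2)cc1`, with the change 3-hydroxypyrrolidin-1-yl in place of (1-carboxy-2-hydroxypropyl)amino on a saturated chain carbon bound to an aromatic carbon. Going by the values given here, the one measured step, a step that the two limits leave unreadable from compound 1 to compound 2, gives no size to carry over. The two compounds with a free carboxy group sit at the limit of > 10000 nM in this assay, at which 2 of the 3 values shown sit. Compound 3, with no free carboxy group, gives 1900 nM, a number rather than a limit. A gain in this assay is therefore expected, resting on that single value. The estimate amounts to an at least 6.6-fold lower number from compound 2 to compound 4 (0.82 log units; beyond the scatter), an expected gain of uncertain size. The estimated value for compound 4 is 1500 nM, with an expected range of 300 nM to 8000 nM.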

Compound 4, half-maximal inhibitory concentration: 7200 nM
Compound 4: middle estimate off by 4.8-fold (0.68 log units), on the low side, within the range that was stated.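

On the saturated chain carbon bound to an aromatic carbon, 3-hydroxypyrrolidin-1-yl gives a number rather than a limit: in this assay compound 4 gives 7200 nM. From the compounds shown here alone, the step reads as an at least 1.3-fold lower number from compound 2 to compound 4 (0.14 log units; that floor lies within the scatter), and likewise as an at least 1.3-fold lower number from compound 1 to compound 4 (0.14 log units; that floor lies within the scatter), so both are floors and their true sizes remain unknown. Compound 1 and compound 2 remain limits of the assay, not numbers: the limit of > 10000 nM in this assay, at which 2 of the 4 values shown sit.

Still open, going by these compounds, is whether the 3-hydroxy group or the absence of the carboxylic acid accounts for the measurable value of compound 4. An unsubstituted pyrrolidine and a methyl ester of the 2-carboxypiperidin-1-yl group at this place would separate the two.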